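Notes on compound 4, an isomer of compound 2

The source may report more compounds than this note shows. Statements on the series, on what has been measured and on what is new or still open speak of the compounds shown alone.

Compound 2 `C/N=C(/NC#N)NCCCCCCn1nc(-c2ccccc2)ccc1=O` carries a cyanoguanidine on its side chain. In a functional assay on the whole organism (stomach) with Rattus norvegicus as the target (a higher number here means that more compound is needed for the effect, a lower number that less compound is needed), compound 2 gives > 100 mg/kg, which is a limit of the assay and not a number. Compound 1 `C/N=C(/NC#N)NCCCCn1nc(N(C)C)ccc1=O` also gives > 100 mg/kg in this assay, again only a limit. Going by the values given here, compound 3 `C/N=C(\S)NCCCCn1nc(-c2ccccc2)ccc1=O`, which carries a thiourea instead, gives 28.9 mg/kg in this assay and is the only compound here with a number. Compound 2 therefore stands at the limit of > 100 mg/kg in this assay, at which 2 of the 3 values shown sit, so no number of its own can anchor a step away from it.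

Compound 4 `CN(C)/C(=N/CCCCCn1nc(-c2ccccc2)ccc1=O)NC#N` differs from compound 2 by a group of 8 heavy atoms (4 carbon, 4 nitrogen; no ring) in place of a group of 8 heavy atoms (4 carbon, 4 nitrogen; no ring), on a saturated chain carbon, five bonds along the chain from an aromatic nitrogen; the two share the same atoms, joined differently, with one hydrogen-bond donor fewer in the entering group. Among the compounds with values here, no measured pair shows a change of this kind, so the size of the step cannot be read from a neighbour. The step from compound 2 to compound 4 in this assay is expected to be small, not beyond the scatter, in either direction, and so compound 4 is expected to remain close to where compound 2 sits an at least 1.1-fold lower number from compound 2 to compound 4 (0.04 log units; that floor lies within the scatter).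

Compound 4 is estimated at 90 mg/kg in this assay, within 25 mg/kg to 250 mg/kg, with a real chance that only a limit is returned again.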

Compound 4, dose for half-maximal effect: 81.5 mg/kg
For compound 4 the middle estimate is 1.1-fold (0.04 log units) above the measured one; measured number inside the range.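

In this assay, going by these compounds alone, the exchange of one group for its isomer, on a saturated chain carbon, five bonds along the chain from an aromatic nitrogen, gives the first step that can be read at all: an at least 1.2-fold lower number from compound 2 to compound 4 (0.08 log units; that floor lies within the scatter). Compound 4 returns a number, 81.5 mg/kg, so this change, with 1 hydrogen-bond donor in the entering group against 2 in the group that leaves, goes with a measurable value. The step is a floor and not a size, and that floor lies within the scatter, since compound 2 stands at a limit of the assay and not at a number: the limit of > 100 mg/kg in this assay, at which 2 of the 4 values shown sit.

As far as these compounds go, how far compound 4 truly lies from compound 2 stays open, and a single pair cannot show whether the donor count has any bearing on the value. Also open, from the compounds shown here alone, is whether a urea or a primary amine at this place on the chain would return a number in this assay, and how such a group would compare with the entering group of compound 4.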